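Cyano in Place of Chloro on a Shared Core

This account rests on a few compounds, and the source may have more. Where it says the series, first, only, none or still open, it means among the compounds named here.

Measured so far:
compound 1, `CN(C(=O)c1ccccc1)c1ccc2[nH]c(-c3n[nH]c4ccccc34)cc2n1`, 13800 nM
compound 2, `COc1cccc(C(=O)N(C)c2ccc3[nH]c(-c4n[nH]c5ccccc45)cc3n2)c1`, 14900 nM
compound 3, `CN(C(=O)c1ccccc1)c1ccc2[nH]c(-c3n[nH]c4cc(Cl)ccc34)cc2n1`, 9590 nM

In a functional assay on A549 cells (Homo sapiens) for antiproliferative activity, read by MTT assay, with a stated time of 72 h (on this read-out higher numbers stand for weaker inhibition and lower numbers for stronger inhibition), compound 3 has the lowest of the three numbers, yet its gaps to compound 1 and compound 2 both lie within the scatter, so no order among them can be claimed. Compound 4, `CN(C(=O)c1ccccc1)c1ccc2[nH]c(-c3n[nH]c4cc(C#N)ccc34)cc2n1`, differs from compound 3 by cyano in place of chloro on an aromatic carbon. Two single-site changes on an aromatic carbon of this core have been measured: a 1.1-fold higher number from compound 1 to compound 2 (0.03 log units; within the scatter) and a 1.4-fold lower number from compound 1 to compound 3 (0.16 log units; within the scatter), each within the scatter. From these, compound 4 is expected to show a 1.0-fold higher number from compound 3 to compound 4 (0.02 log units; within the scatter), no step beyond the scatter. The estimate for compound 4 in this assay is 10000 nM, with a range from 4000 nM to 25000 nM.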

Compound 4, half-maximal inhibitory concentration: 32800 nM
For compound 4 the middle estimate is 3.3-fold (0.52 log units) below the measured one; measured number above the stated range.
By their numbers in this assay, from the lowest: compounds 3, 1 and 2 (each within the scatter of the next); then compound 4.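

In this assay, among the compounds shown here, this aromatic carbon of the shared core gives the first steps beyond the scatter: cyano in place of chloro gives a 3.4-fold higher number from compound 3 to compound 4 (0.53 log units; beyond the scatter) and cyano in place of hydrogen gives a 2.4-fold higher number from compound 1 to compound 4 (0.38 log units; beyond the scatter) as modest steps toward weaker inhibition. The position therefore responds to the group it carries, which the within-scatter change from hydrogen to chloro did not show. No measurement at hand bears on why cyano has this effect. From the compounds shown here alone, whether an amine or a carboxylic acid at this carbon would also give weaker inhibition remains open.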